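The compounds below may be only part of what the source reports. "The series", "measured", "known", "first", "only" and "open" are said of these compounds alone.

Compound 1 `Cc1ccccc1COc1ccc(-c2cc(CN3CCN(Cc4ccc(C(F)(F)F)cc4)CC3)no2)cc1`: 1200 nM
Compound 2 `Fc1cccc(COc2ccc(-c3cc(CN4CCN(Cc5ccc(C(F)(F)F)cc5)CC4)no3)cc2)c1`: 1300 nM

Among the compounds with values here, in a functional assay on Huh-7 cells (Homo sapiens) for antiproliferative activity, read by sulforhodamine B assay, with a stated time of 72 h (a lower number here means a stronger inhibitor, a higher number a weaker inhibitor), compound 2 has the numerically higher of the two values, yet the only measured step, a 1.1-fold higher number from compound 1 to compound 2 (0.03 log units; within the scatter), lies within the scatter, so the two compounds cannot be told apart. Compound 3 `COc1cc(COc2ccc(-c3cc(CN4CCN(Cc5ccc(C(F)(F)F)cc5)CC4)no3)cc2)cc(OC)c1` differs from compound 2 in one place: 3,5-dimethoxyphenyl in place of 3-fluorophenyl on a saturated chain carbon bound to an oxygen on an aromatic ring. The step of a 1.1-fold higher number from compound 1 to compound 2 (0.03 log units; within the scatter) also exchanged the group at this same place without moving the value beyond the scatter. On that single comparison, the step of no change at the digits printed from compound 2 to compound 3 (within the scatter) is expected to stay within the scatter too. Compound 3 is therefore estimated at 1300 nM in this assay, with a range from 600 nM to 2800 nM.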

Compound 3, half-maximal inhibitory concentration: 1500 nM
Compound 3: middle estimate off by 1.2-fold (0.06 log units), on the low side; measured number inside the range.
By their numbers in this assay, from the lowest: compounds 1, 2 and 3 (each within the scatter of the next).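

Swapping 3-fluorophenyl for 3,5-dimethoxyphenyl is a bigger change than the earlier one: the entering group has more heavy atoms and carries hydrogen-bond acceptors, which 3-fluorophenyl lacks. Even so, this assay shows a 1.2-fold higher number from compound 2 to compound 3 (0.06 log units; within the scatter), and the wider comparison gives a 1.3-fold higher number from compound 1 to compound 3 (0.10 log units; within the scatter), so all three aryl groups at this place remain indistinguishable. Nothing available explains this lack of separation.

From the compounds shown here alone, it remains open whether an amine or a carboxylic acid on this ring would move the value beyond the scatter. The same applies to a longer chain in place of the benzyl carbon.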